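Ester in Place of Chloro on the Imidazole Core

The source may report more compounds than this note shows. Statements on the series, on what has been measured and on what is new or still open speak of the compounds shown alone.

In a functional assay on CHO cells for antagonist activity at transient receptor potential cation channel subfamily V member 1 (Rattus norvegicus), read by calcium flux, at pH 5 (on this read-out lower numbers stand for stronger inhibition and higher numbers for weaker inhibition), compound 1 `Fc1cc(-c2nc(N3CCN(c4ncccc4C(F)(F)F)CC3)[nH]c2-c2ccc(C(F)(F)F)cc2)cc(F)c1F` gives 20 nM. Compound 2 `FC(F)(F)c1ccc(-c2[nH]c(N3CCN(c4ncccc4C(F)(F)F)CC3)nc2Cl)cc1` reaches only the limit of the assay, > 4000 nM, so its true number is not known. Among the measured compounds shown here, the single measured step, an at least 200-fold higher number from compound 1 to compound 2 (2.30 log units; beyond the scatter), shows how much is lost when the aromatic group at that position is traded for a small halogen; that limit is recorded as the limit of > 4000 nM in this assay, at which 1 of the 2 values shown sits. Compound 3 `COC(=O)c1nc(N2CCN(c3ncccc3C(F)(F)F)CC2)[nH]c1-c1ccc(C(F)(F)F)cc1` carries methoxycarbonyl in place of chloro on an aromatic carbon, a group larger than chloro but still far from the aromatic ring of compound 1. The step to compound 1 gives the only scale, and it speaks for a position that tolerates a large group, so compound 3 is expected to lie somewhere between the two measured points. Compound 3 is therefore estimated at 1500 nM, within 150 nM to 8000 nM. That amounts to an expected at least 2.6-fold lower number from compound 2 to compound 3 (0.42 log units; beyond the scatter) in this assay, though a second limit remains possible.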

Compound 3, half-maximal inhibitory concentration: 180 nM
Beside the measured number, compound 3's estimate is 8.3-fold (0.92 log units) above it; the measured number falls inside the stated range.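

In this assay, the change on this aromatic carbon gives an at least 22-fold lower number from compound 2 to compound 3 (1.34 log units; beyond the scatter), so a group without a ring can restore a measurable inhibition that chloro does not show. The position therefore does not depend on an aromatic group alone, yet methoxycarbonyl does not match 3,4,5-trifluorophenyl, with a 9.0-fold higher number from compound 1 to compound 3 (0.95 log units; beyond the scatter). The first of these steps gives only a lower bound on the gain and not its true size, since compound 2 has no exact number: the limit of > 4000 nM in this assay, at which 1 of the 3 values shown sits.

With only these three groups shown, it stays open whether the gain rests on the carbonyl or on the methoxy part, which a carboxylic acid, a primary amide or a hydroxymethyl group on this carbon could separate. Also open, from the compounds shown here alone, is how an unsubstituted phenyl ring would compare with the 3,4,5-trifluorophenyl group of compound 1.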